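Changing the sulfur substituent of compound 1

This account rests on a few compounds, and the source may have more. Where it says the series, first, only, none or still open, it means among the compounds named here.

Measured in a functional assay on DU-145 cells (Homo sapiens) for inhibition, read by trypan blue exclusion, with a stated time of 96 h; on this read-out lower numbers stand for stronger inhibition of growth and higher numbers for weaker inhibition of growth:
- compound 1 `Cc1ccc(S/C(=C/c2cc(Cl)cc(Cl)c2Cl)C(=O)c2ccc(Cl)cc2)cc1`: 50000 nM
- compound 2 `Cc1ccc(S/C(=C/c2cc(C)cc(C)c2)C(=O)c2ccc(Cl)cc2)cc1`: 50000 nM

Compound 1 stands at 50000 nM in this assay, level with compound 2 at the digits shown. Neither compound therefore ranks above the other.

The next compound to be tested is compound 3 `O=C(/C(=C\c1cc(Cl)cc(Cl)c1Cl)Sc1ccccc1Br)c1ccc(Cl)cc1`, which has 2-bromophenyl in place of 4-methylphenyl on a sulfur. The count of heavy atoms in the group stays the same, but a methyl-bearing ring gives way to a bromine-bearing one.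

Among the compounds with values here, only one measured step is available. Putting 3,5-dimethylphenyl in place of 2,3,5-trichlorophenyl gave no change at the digits printed from compound 1 to compound 2 (within the scatter). That change lies on a double-bonded chain carbon, not on the sulfur, so it offers only indirect guidance. Within the data shown here, no measured step shows what a change on the sulfur does.

With so little evidence, no shift beyond the scatter is expected, and the expected step is a 1.4-fold lower number from compound 1 to compound 3 (0.15 log units; within the scatter). A real gain in growth inhibition cannot be ruled out, so the range is wide. For compound 3 the estimated value is 35000 nM, with an expected range of 5000 nM to 70000 nM.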

Compound 3, concentration for 50% growth inhibition: 25000 nM
Estimate against measurement, compound 3: 1.4-fold (0.15 log units) above, within the range that was stated.
By their numbers in this assay, from the lowest: compounds 3, 1 and 2 (each within the scatter of the next).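

Within the data shown here, this result gives the first reading of a change on the sulfur: in this assay, 2-bromophenyl in place of 4-methylphenyl gives a 2.0-fold lower number from compound 1 to compound 3 (0.30 log units; within the scatter). The two groups therefore cannot be told apart here, even though a methyl-bearing ring gives way to a bromine-bearing one, and this single swap on the sulfur shows no shift beyond the scatter, as the change on the double-bonded chain carbon also did. No accompanying measurement offers an explanation for this outcome.

All of this rests on one pair of sulfur substituents that match in heavy-atom count and ring type and carry no hydrogen-bond donors or acceptors, so it says little about the position as a whole. The compounds shown leave open whether a carboxylic acid or an amine on that ring, or a longer chain in place of the ring, would move the number beyond the scatter, and whether 2-bromophenyl on the sulfur would read the same alongside the 3,5-dimethylphenyl of compound 2.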